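Replacing the pyridone by a methyl: what permeability to expect

A few compounds are considered here, and "the series" means these few. Any claim that something is new, unique, unknown or untested is made for them only; others in the source may bear on it.

Measured so far:
compound 1, `CCCCc1nc(=O)c(S(=O)(=O)c2ccc(-c3ccc(F)nc3)cc2)c(O)n1-c1c(OC)cccc1OC`, 24 nm/s
compound 2, `CCCCc1nc(=O)c(S(=O)(=O)c2ccc(-n3ccccc3=O)cc2)c(O)n1-c1c(OC)cccc1OC`, 1 nm/s

Among the compounds with values here, compound 2 gives the lowest of the two numbers so far in an ADME assay for permeability, using PAMPA, at pH 7.4; a higher number here means that the compound crosses the layer faster, a lower number that the compound crosses the layer more slowly; its nearest neighbour is compound 1, with 24 nm/s. Within the data shown here, the only step measured between them, a 24-fold lower number from compound 1 to compound 2 (1.38 log units; beyond the scatter), was large and downward, and is the one that bears on the next change.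

Compound 3, `CCCCc1nc(=O)c(S(=O)(=O)c2ccc(C)cc2)c(O)n1-c1c(OC)cccc1OC`, keeps the shared core of compound 2 and differs from it in one place: one carbon atom in place of a group of 7 heavy atoms (5 carbon, 1 nitrogen, 1 oxygen; one six-membered aromatic ring with 1 hetero atom), on an aromatic carbon. The group that leaves in this change is the same group whose arrival, in the step from compound 1 to compound 2, went with the large fall in this assay. Its removal in favour of a methyl is therefore expected to move the number upward by a step of at least similar size, a 40-fold higher number from compound 2 to compound 3 (1.60 log units; beyond the scatter).

On that basis, compound 3 is estimated at 40 nm/s in this assay, with a range from 10 nm/s to 150 nm/s.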

Compound 3, apparent permeability: 7 nm/s
Compound 3: the middle estimate sits 5.7-fold (0.76 log units) above what was measured; measured number below the stated range.
By their numbers in this assay, from the lowest: compound 2; then compound 3; then compound 1.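

In this assay, the methyl is a middle point that the first two compounds could not supply, and it lets the two larger groups be read separately against a small one: the change gives a 7.0-fold higher number from compound 2 to compound 3 (0.85 log units; beyond the scatter), while the same methyl gives a 3.4-fold lower number from compound 1 to compound 3 (0.54 log units; beyond the scatter), so the steps at this position run in opposite directions. Size alone therefore does not order the series, since the 6-fluoropyridin-3-yl group and the pyridone group both hold 7 heavy atoms and lie on either side of the methyl, which holds one; the earlier large step between them thus splits into a rise from the methyl to the former and a fall from the methyl to the latter. What lies behind this order cannot be said from anything available here.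

Within the data shown here, with only three groups at this position, the compounds leave open whether the higher number of compound 1 belongs to an aromatic ring attached through carbon or to its fluorine. They also leave open where a plain phenyl, a morpholine or a carboxylic acid in the same place would fall relative to the methyl.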